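From methoxy to (oxiran-2-yl)methoxy on compound 3

The source may report more compounds than this note shows. Statements on the series, on what has been measured and on what is new or still open speak of the compounds shown alone.

In a functional assay on SK-OV-3 cells (Homo sapiens) for cytotoxicity (a higher number here means a weaker inhibitor of growth, a lower number a stronger inhibitor of growth), compound 1 (`CSc1ccc(C2=C(c3ccc(C)c(C)c3)C(=O)N3CCCC3C2)cc1`) gives 300 nM and compound 2 (`CSc1ccc(C2=C(c3ccc(F)c(C)c3)C(=O)N3CCCC3C2)cc1`) gives 300 nM, with no change at the digits printed from compound 1 to compound 2 (within the scatter). Compound 3 (`COc1ccc(C2=C(c3ccc(SC)cc3)CC3CCCN3C2=O)cc1`) has the highest number of the three at 3000 nM.

Compound 4 (`CSc1ccc(C2=C(c3ccc(OCC4CO4)cc3)C(=O)N3CCCC3C2)cc1`) differs from compound 3 in one place: oxiran-2-yl in place of hydrogen on a saturated chain carbon bound to an oxygen on an aromatic ring. Methoxy thus becomes (oxiran-2-yl)methoxy.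

Among the measured compounds shown here, no measured step changes a group on that oxygen, so the evidence is indirect. The nearest steps replace the whole aryl group on the same double-bonded ring carbon: a 10-fold higher number from compound 1 to compound 3 (1.00 log units; beyond the scatter) and a 10-fold higher number from compound 2 to compound 3 (1.00 log units; beyond the scatter). They show that this aryl group can move the number beyond the scatter, but they say nothing about the new group itself. A smaller step than these is expected, leaning towards a lower number, though the direction is uncertain. The expected move is a 2.0-fold lower number from compound 3 to compound 4 (0.30 log units; within the scatter). For compound 4 the estimate is 1500 nM, with an expected range of 300 nM to 6000 nM.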

Compound 4, concentration for 50% growth inhibition: 10000 nM
Beside the measured number, compound 4's estimate is 6.7-fold (0.82 log units) below it; the measured number lies above the stated range.
By their numbers in this assay, from the lowest: compounds 1 and 2 (each within the scatter of the next); then compound 3; then compound 4.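

In this assay a change confined to the methoxy group, oxiran-2-yl in place of hydrogen on a saturated chain carbon bound to an oxygen on an aromatic ring, gives a 3.3-fold higher number from compound 3 to compound 4 (0.52 log units; beyond the scatter) and so reads beyond the scatter. The earlier steps shown here exchanged the whole aryl group on the double-bonded ring carbon, whereas this one shows that extending the group on that oxygen is enough on its own to raise the number. Nothing available bears on why the number moves.

Still open, as far as these compounds go, is whether the rise follows from the oxirane ring itself or from any group of similar size, which cyclopropylmethoxy, its all-carbon counterpart, would help to separate. From the compounds shown here alone, the effect of an amine or a carboxylic acid at the end of that chain also remains open.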